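From 2-hydroxyethyl to 2-hydroxy-1,1-bis(hydroxymethyl)ethyl

The source may report more compounds than this note shows. Statements on the series, on what has been measured and on what is new or still open speak of the compounds shown alone.

Going by the values given here, in a functional assay on SW-620 cells (Homo sapiens) for inhibition, read by MTT assay, with a stated time of 4 days (a higher number here means a weaker inhibitor, a lower number a stronger inhibitor), compound 1 `COc1cc(NC(C)CCCNC(=O)NNC(=O)Nc2ccc(Cl)c(C(F)(F)F)c2)c2ncccc2c1` gives 15000 nM, the only exact value in this small set. Compound 2 `COc1cc(NC(C)CCCNC(=O)NN)c2ncccc2c1` reads > 100000 nM, which is a limit. Compound 3 `COc1cc(NC(C)CCCNC(=O)NNC(=O)NCCO)c2ncccc2c1` reads > 100000 nM, which is also a limit. Compound 3 therefore stands at the limit of > 100000 nM in this assay, at which 2 of the 3 values shown sit.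

Compound 4 `COc1cc(NC(C)CCCNC(=O)NNC(=O)NC(CO)(CO)CO)c2ncccc2c1` changes compound 3 on an amide-type nitrogen: 2-hydroxy-1,1-bis(hydroxymethyl)ethyl in place of 2-hydroxyethyl on an amide-type nitrogen. The closest measured evidence is an at least 6.6-fold higher number from compound 1 to compound 3 (0.82 log units; beyond the scatter), which lies beyond the scatter and comes from 2-hydroxyethyl in place of 4-chloro-3-(trifluoromethyl)phenyl on that same nitrogen. The other relevant change gives no size: a step that the two limits leave unreadable from compound 2 to compound 3. Neither step gives a reason to expect a lower number in this assay, so compound 4 is expected to remain at the limit, with no readable gain. The estimated change is a number no higher from compound 3 to compound 4 (the limit leaves the size open). For compound 4, the expected value is 100000 nM, with an estimated range of 40000 nM to 200000 nM.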

Compound 4, half-maximal inhibitory concentration: > 100000 nM
Compound 4: only a limit was reported (the forecaster's own chance of this, stated with the estimate: 80%); the middle value lies on the limit itself.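

Replacing 2-hydroxyethyl with 2-hydroxy-1,1-bis(hydroxymethyl)ethyl on this amide-type nitrogen yields no exact value in this assay: compound 4 gives > 100000 nM, which is a limit. The steps to compound 4 from compound 2 and from compound 3 cannot be read, as both ends of each are limits. The one readable step is an at least 6.6-fold higher number from compound 1 to compound 4 (0.82 log units; beyond the scatter), so a second group without a ring in place of 4-chloro-3-(trifluoromethyl)phenyl on this nitrogen also leaves the reading at the limit, where the set now gathers: the limit of > 100000 nM in this assay, at which 3 of the 4 values shown sit.

As far as these compounds go, how far compound 3 and compound 4 lie past that limit remains unknown, so any difference between their two groups stays hidden. Only compound 1 has an exact value, which leaves open whether an unsubstituted phenyl or a longer alkyl chain on this nitrogen would give a readable number.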